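Varying the Alkoxy Substituent of a Pyridine-Based Vanilloid Receptor Antagonist

The compounds below may be only part of what the source reports. "The series", "measured", "known", "first", "only" and "open" are said of these compounds alone.

Three compounds sharing one core have been measured:

Compound 1 `CCCOc1nc(C(C)(C)C)ccc1CNC(=O)C(C)c1ccc(NS(C)(=O)=O)c(F)c1`: 1.7 nM
Compound 2 `CCCCCCOc1nc(C(C)(C)C)ccc1CNC(=O)C(C)c1ccc(NS(C)(=O)=O)c(F)c1`: 2.7 nM
Compound 3 `CCCCSc1nc(C(C)(C)C)ccc1CNC(=O)C(C)c1ccc(NS(C)(=O)=O)c(F)c1`: 3.2 nM

In an assay on cells for antagonist activity at transient receptor potential cation channel subfamily V member 1 (Homo sapiens), read by FLIPR and calcium flux, with a stated time of 6 min (a higher number here means a weaker inhibitor, a lower number a stronger inhibitor), compound 1 gives the lowest of the three numbers, but its neighbours sit close: the step of a 1.6-fold higher number from compound 1 to compound 2 (0.20 log units; within the scatter) and the step of a 1.9-fold higher number from compound 1 to compound 3 (0.27 log units; within the scatter) both stay within the scatter, and the step of a 1.2-fold higher number from compound 2 to compound 3 (0.07 log units; within the scatter) is smaller still. Across these three compounds, changing the group on the aromatic carbon of the core has left the inhibition constant essentially unmoved.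

Compound 4 `CC(C(=O)NCc1ccc(C(C)(C)C)nc1C1CCCCC1)c1ccc(NS(C)(=O)=O)c(F)c1` has not yet been measured in this assay. It differs from compound 1 in one place: cyclohexyl in place of propoxy on an aromatic carbon. The measured steps that bear on this change are those in which the same aromatic carbon carried propoxy, hexyloxy or butylsulfanyl, and none of them moved the number beyond the scatter. For the measured compounds named here, a cyclohexyl group in this position has no measured precedent here, and a ring in place of a chain is a larger structural departure than the chain variations already seen, so a wider range is warranted.

On that basis compound 4 is expected to give about 3.5 nM in this assay, within a range of 1 nM to 12 nM, which would mean an expected step of a 2.1-fold higher number from compound 1 to compound 4 (0.31 log units; beyond the scatter).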

Compound 4, inhibition constant: 3.1 nM
Compound 4: middle estimate off by 1.1-fold (0.05 log units), on the high side; the measured number falls inside the stated range.
By their numbers in this assay, from the lowest: compounds 1, 2, 4 and 3 (each within the scatter of the next).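

For the compounds shown here, until this result, the aromatic carbon next to the ring nitrogen had carried only open chains attached through oxygen or sulfur, whereas cyclohexyl places a six-membered non-aromatic ring of carbon only on that carbon and removes the oxygen of propoxy, and in this assay this change still gives a 1.8-fold higher number from compound 1 to compound 4 (0.26 log units; within the scatter) and so does not separate compound 4 from compound 1. The comparisons with the other two chains read the same way, with a 1.1-fold higher number from compound 2 to compound 4 (0.06 log units; within the scatter) and a 1.0-fold lower number from compound 3 to compound 4 (0.01 log units; within the scatter) both showing that the ring sits among the chains, so that across compounds 1 to 4 neither a ring in place of a chain nor a carbon in place of oxygen or sulfur at the point of attachment moves the number beyond the scatter. Nothing available here offers an explanation of why these four groups give such similar numbers.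

What the compounds shown leave open is whether this carbon would accept groups of a different kind, such as an amine, a carboxylic acid or a phenyl ring, as readily as it accepts cyclohexyl. They also leave open whether a much smaller group, such as methoxy or cyclopropyl, would stay within the same narrow span.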